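The compounds below may be only part of what the source reports. "The series", "measured", "known", "first", "only" and "open" are said of these compounds alone.

Measured so far in an ADME assay on BJ cells (Homo sapiens), read by MTT assay, with a stated time of 72 h; on this read-out lower numbers stand for stronger inhibition and higher numbers for weaker inhibition:
compound 1 `COc1ncnc2c1c(-c1ccccc1)cn2[C@@H]1O[C@H](CO)[C@@H](O)[C@H]1O` gives > 100000 nM as a limit
compound 2 `CNc1ncnc2c1c(-c1cccs1)cn2[C@@H]1O[C@H](CO)[C@@H](O)[C@H]1O` gives > 100000 nM as a limit

Compound 2 stands at > 100000 nM in this assay as a limit of the assay, not as a number. Both measured compounds sit at the limit of > 100000 nM in this assay, at which 2 of the 2 values shown sit, and so give no number to work from.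

Going to compound 3 `CNc1ncnc2c1c(-c1ccccc1)cn2[C@@H]1O[C@H](CO)[C@@H](O)[C@H]1O`, the structural change is phenyl in place of thiophen-2-yl on an aromatic carbon and it puts phenyl in place of thiophen-2-yl on an aromatic carbon. Going by the values given here, no measured step shows what this swap does in this assay. No change beyond the scatter is expected because of the limit of > 100000 nM in this assay, at which 2 of the 2 values shown sit, and nothing measured points the other way. The step of an at least 1.1-fold lower number from compound 2 to compound 3 (0.04 log units; that floor lies within the scatter) is therefore expected to be small. The estimate for compound 3 is 90000 nM with an expected range of 30000 nM to 100000 nM in this read-out.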

Compound 3, half-maximal inhibitory concentration: > 100000 nM
Compound 3: only a limit was reported; the forecaster's own chance of this, stated with the estimate: 80%; middle value at least 1.1-fold (0.04 log units) from the limit.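

In this assay compound 3 gives > 100000 nM, a limit of the assay and not a number. No step from compound 1 or compound 2 to compound 3 can be read: the limit of > 100000 nM in this assay, at which 3 of the 3 values shown sit.

The compounds shown leave open what either the phenyl for thiophen-2-yl swap or the methylamino for methoxy swap does to the read-out.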